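Quinazoline series, furfurylamine side chain: butyl against pentyl

The source may hold more compounds than are shown below. What is called first, only, known or untested is meant among the compounds shown, and "the series" means these compounds.

Measured so far:
- compound 1, `CCCCNc1nc(NCc2ccco2)c2ccccc2n1`: 92.3%
- compound 2, `CCCCCNc1nc(NCc2ccco2)c2cc(F)ccc2n1`: "not determined" (no result reported)

In a functional assay on HT-29 cells (Homo sapiens) for cytotoxicity, read by MTT assay, with a stated time of 2 days, tested at 10 uM (on this read-out lower numbers stand for less inhibition and higher numbers for more inhibition at the one concentration tested (going by the name of the read-out)), compound 1 gives 92.3%. Compound 2, `CCCCCNc1nc(NCc2ccco2)c2cc(F)ccc2n1`, was run but in this assay compound 2 gives "not determined" (no result reported), so it stands on no number and nothing can be read off it. Compound 3, `CCCCNc1nc(NCc2ccco2)c2cc(F)ccc2n1`, is the next to be measured; relative to compound 2 it shows (hydrogen in place of methyl on a saturated chain carbon, four bonds along the chain from a nitrogen on an aromatic ring). Within the data shown here, with no value for compound 2, no step between the two can be stated, and nothing in the pair of them points to a direction; the expectation is that the change from pentyl to butyl on this chain gives no shift beyond the usual scatter. Among the measured compounds shown here, the only anchor is compound 1, whose reading of 92.3% sits high. Compound 3 is therefore expected to fall near 85%, within 60% to 98%.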

Compound 3, a percentage reported as inhibition, at one concentration (the size of the read-out at that concentration, not a potency): 88.1%
For compound 3 the middle estimate is 3.1 percentage points below the measured one, and the stated range covers the measured number.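

In this assay, fluoro in place of hydrogen on an aromatic carbon of the shared core gives a number 4.2 percentage points lower from compound 1 to compound 3 (within the scatter), so with the butyl chain held constant, this one change does not separate the two readings beyond the scatter. Compound 2 has no result, so the step from it to compound 3 cannot be read, and the methyl to hydrogen change on the chain remains without a number. Nothing available on these compounds bears on the reason for this reading.

Still open, as far as these compounds go, is whether chloro or methoxy in place of the fluoro would give a reading apart from that of compound 3. Also open, from the compounds shown here alone, is how a hexyl chain, or a butyl chain ending in an amine or a carboxylic acid, would read on the core of compound 3.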